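A few compounds are considered here, and "the series" means these few. Any claim that something is new, unique, unknown or untested is made for them only; others in the source may bear on it.

In a functional assay on L1210 cells (Mus musculus) for inhibition, read by MTT assay (a higher number here means a weaker inhibitor, a lower number a stronger inhibitor), compound 2 `CCCCNC(=O)N1CC1C#N` gives 12000 nM, the highest of the three numbers recorded so far. Compound 3 `N#CC1CN1C(=O)Nc1ccc(F)cc1` gives 7300 nM, which lies within the scatter of compound 2, while compound 1 `N#CC1CN1C(=O)Nc1ccc(Cl)c(Cl)c1` gives 2600 nM, a gap that goes beyond the scatter. The step from compound 2 leads to compound 4 `N#CC1CN1C(N)=O`, a change of hydrogen in place of butyl on an amide-type nitrogen. Among the measured compounds shown here, no measured pair shows this change, so nothing among the measured compounds sets its size or direction. The estimated step of a 1.7-fold higher number from compound 2 to compound 4 (0.22 log units; within the scatter) is expected to be small, leaning toward a higher number, and it may not exceed the scatter. Compound 4 is expected to give about 20000 nM in this assay, with a range from 5000 nM to 60000 nM.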

Compound 4, half-maximal inhibitory concentration: > 90000 nM
Compound 4 gave a limit, no number; the forecaster's own chance of this, stated with the estimate: 15%; middle value at least 4.5-fold (0.65 log units) away from the limit.
By their numbers in this assay, from the lowest: compound 1; then compounds 3 and 2 (each within the scatter of the next). At a limit, above all of these: compound 4.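

Hydrogen in place of butyl on the amide-type nitrogen gives an at least 7.5-fold higher number from compound 2 to compound 4 (0.87 log units; beyond the scatter). Among the compounds shown here, this is the first readable step at this position, and it shows that in this assay losing the butyl group moves the number upward beyond the scatter. The full size of that step stays unknown, as compound 4 gives a limit and not a number: the limit of > 90000 nM in this assay, at which 1 of the 4 values shown sits.

The compounds shown leave open whether a methyl or ethyl group on this nitrogen would be enough to bring the number back towards that of compound 2. They also leave open how a longer chain, such as octyl, would read.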